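Fluoro in place of bromo: a small step expected

The compounds below may be only part of what the source reports. "The series", "measured", "known", "first", "only" and "open" are said of these compounds alone.

In a functional assay on microsomes from liver (Rattus norvegicus, strain Wistar) for inhibition, read by spectrophotometry, with a stated time of 60 min (on this read-out lower numbers stand for stronger inhibition and higher numbers for weaker inhibition), compound 1 `COc1ccc(C(=O)ON=C2CC(c3ccc(O)c(OC)c3)N(C)C(c3ccc(O)c(OC)c3)C2)cc1` gives 40000 nM and compound 2 `COc1cc(C2CC(=NOC(=O)c3ccc(Br)cc3)CC(c3ccc(O)c(OC)c3)N2C)ccc1O` gives 112000 nM as its reading. Compound 2 therefore holds the higher of the two numbers, making it the weaker inhibitor of this pair.

Compound 3 `COc1cc(C2CC(=NOC(=O)c3ccc(F)cc3)CC(c3ccc(O)c(OC)c3)N2C)ccc1O` has not yet been measured. It comes from compound 2 by a single swap, fluoro in place of bromo on an aromatic carbon of a six-membered aromatic ring of carbon only, para to a large group.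

For the measured compounds named here, one measured step bears on this swap: a 2.8-fold higher number from compound 1 to compound 2 (0.45 log units; beyond the scatter) is a modest change that came with bromo in place of methoxy on an aromatic carbon. Going by the values given here, it shows that a swap of this kind can move the number, but no fluoro compound has been measured, so the direction stays uncertain. In this assay a small move toward a lower number is expected, and the estimated step is a 1.7-fold lower number from compound 2 to compound 3 (0.24 log units; within the scatter) in size. For compound 3 the estimated value is 65000 nM with an expected range from 25000 nM to 150000 nM as the likely span.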

Compound 3, half-maximal inhibitory concentration: 140000 nM
Estimate against measurement, compound 3: 2.2-fold (0.33 log units) below; the range from low to high includes it.
By their numbers in this assay, from the lowest: compound 1; then compounds 2 and 3 (each within the scatter of the next).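

In this assay, fluoro in place of bromo on an aromatic carbon, para to a large group, gives a 1.3-fold higher number from compound 2 to compound 3 (0.10 log units; within the scatter), so at this place the two halogens cannot be told apart. Fluoro in place of methoxy gives a 3.5-fold higher number from compound 1 to compound 3 (0.54 log units; beyond the scatter), which leaves compound 1 as the strongest inhibitor of the three and shows that the gap seen earlier was not special to bromo: it separates methoxy from both halogens tried. This is something compound 1 and compound 2 alone could not show, but no supporting measurement bears on the result, so the data give no explanation for it.

Three compounds cannot show whether methoxy improves inhibition or both halogens weaken it, since the unsubstituted phenyl ring, with a hydrogen at this carbon, is not among them to serve as a reference. From the compounds shown here alone, how far the trend reaches also stays open, for example whether an ethoxy group, a longer chain ending in oxygen, or an amine at the same carbon would read closer to compound 1 or to the halogen pair.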